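Trimming the Chain End: From Compound 2 to Compound 3

The source may report more compounds than this note shows. Statements on the series, on what has been measured and on what is new or still open speak of the compounds shown alone.

Compound 1 `CC/N=C(\S)CCn1nc(-c2ccccc2)ccc1=O` and compound 2 `CN(C)C(=S)CCCCCn1nc(-c2ccccc2)ccc1=O` share one core and differ in the chain hung from it. In a functional assay on the whole organism (stomach) with Rattus norvegicus as the target (a higher number here means that more compound is needed for the effect, a lower number that less compound is needed), compound 1 gives 100 mg/kg, and compound 2 gives 100 mg/kg, level with compound 1 within the scatter. Compound 3 `C/N=C(/S)CCCCCn1nc(-c2ccccc2)ccc1=O` has not been tested. It differs from compound 2 by a group of 4 heavy atoms (2 carbon, 1 nitrogen, 1 sulfur; no ring) in place of a group of 5 heavy atoms (3 carbon, 1 nitrogen, 1 sulfur; no ring), on a saturated chain carbon, five bonds along the chain from an aromatic nitrogen. Among the compounds with values here, with no step known between measured pairs, the two matching values are the only anchor, so no shift beyond the scatter is expected for no change at the digits printed from compound 2 to compound 3 (within the scatter). Compound 3 is expected to give 100 mg/kg in this assay, with a range from 40 mg/kg to 250 mg/kg.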

Compound 3, dose for half-maximal effect: 25.2 mg/kg
Estimate against measurement, compound 3: 4.0-fold (0.60 log units) above, outside the stated range (below it).
By their numbers in this assay, from the lowest: compound 3; then compounds 1 and 2 (each within the scatter of the next).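

In this assay, the end of the chain is the first place shown to respond: putting the group of 4 heavy atoms in place of the group of 5 heavy atoms gives a 4.0-fold lower number from compound 2 to compound 3 (0.60 log units; beyond the scatter). The entering group carries 1 hydrogen-bond donor where the leaving group has none, and the change to compound 3 from the shared level also gives a 4.0-fold lower number from compound 1 to compound 3 (0.60 log units; beyond the scatter). Nothing shown accounts for this shift.

As far as these compounds go, whether the donor or the lost carbon matters stays open, as does how an amine at the chain end or a longer chain would read.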